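A second methyl on the saturated ring carbon of compound 3

The source may hold more compounds than are shown below. What is called first, only, known or untested is meant among the compounds shown, and "the series" means these compounds.

Three compounds share one core. In a functional assay on HT-29 cells (Homo sapiens) for antiproliferative activity, read by MTT assay, with a stated time of 72 h (on this read-out lower numbers stand for stronger inhibition and higher numbers for weaker inhibition), compound 1 `COc1cc2c(Oc3ccc(NC(=O)NN4C(=O)CSC4c4c(F)cccc4F)c4ccccc34)ccnc2cc1OCCCN1CCCC1` gives 1860 nM. Compound 2 `COc1cc2c(Oc3c(F)cc(NC(=O)NN4C(=O)CSC4c4c(F)cccc4F)cc3F)ccnc2cc1OCCCN1CCCC1` gives 230 nM, the lowest number of the three. Compound 3 `COc1cc2c(Oc3c(F)cc(NC(=O)NN4C(=O)C(C)SC4c4c(F)cccc4F)cc3F)ccnc2cc1OCCCN1CCCC1` gives 670 nM, the second highest number: compound 2 stands below it and compound 1 above it, both beyond the scatter. Among the measured compounds shown here, the one single-point step recorded so far is a 2.9-fold higher number from compound 2 to compound 3 (0.46 log units; beyond the scatter), a modest weakening for methyl in place of hydrogen on a saturated ring carbon.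

Compound 4 `COc1cc2c(Oc3c(F)cc(NC(=O)NN4C(=O)C(C)(C)SC4c4c(F)cccc4F)cc3F)ccnc2cc1OCCCN1CCCC1` is not yet measured. It differs from compound 3 by methyl in place of hydrogen on a saturated ring carbon, the same kind of change made a second time on that carbon. For the measured compounds named here, the only step that bears on it is a 2.9-fold higher number from compound 2 to compound 3 (0.46 log units; beyond the scatter). For compound 4 a step in the same direction, of similar or somewhat smaller size, is expected in this assay, namely a 1.9-fold higher number from compound 3 to compound 4 (0.29 log units; within the scatter). Compound 4 is therefore estimated at 1300 nM, within a range of 500 nM to 3500 nM.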

Compound 4, half-maximal inhibitory concentration: 950 nM
For compound 4 the middle estimate is 1.4-fold (0.14 log units) above the measured one, within the range that was stated.
By their numbers in this assay, from the lowest: compound 2; then compounds 3, 4 and 1 (each within the scatter of the next, the first and the last beyond it).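

In this assay, the second methyl on this saturated ring carbon gives a 1.4-fold higher number from compound 3 to compound 4 (0.15 log units; within the scatter), so compound 3 and compound 4 cannot be told apart on this read-out. The same change made the first time gave a 2.9-fold higher number from compound 2 to compound 3 (0.46 log units; beyond the scatter), which lies beyond the scatter, so at this position a repeat of the change does not give a second step beyond the scatter, and the position carries two methyl groups with the number staying within the scatter of that of compound 3. No measured property at hand accounts for either step.

Going by these compounds, whether an ethyl group, a longer chain, an amine or a carboxylic acid on this carbon would behave like methyl remains open. Also open, on these data alone, is whether the methyl steps would hold with the other aryl part found in compound 1.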